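A few compounds are considered here, and "the series" means these few. Any claim that something is new, unique, unknown or untested is made for them only; others in the source may bear on it.

Among the compounds with values here, the compounds measured so far are compound 1 `O=C1COc2ccc(-n3cc(C[C@H](O)COCCOC[C@@H](O)Cc4ccc(-c5ccccc5)cc4)nn3)cc2N1`, compound 2 `O[C@H](COCCOC[C@@H](O)Cc1c[nH]nn1)Cc1ccc(-c2ccccc2)cc1` and compound 3 `O[C@H](COCCOC[C@@H](O)Cc1cn(-c2ccc3c(c2)OCCO3)nn1)Cc1ccc(-c2ccccc2)cc1`.

In a functional assay on HCT-116 cells (Homo sapiens) for inhibition, read by MTT assay, with a stated time of 72 h (a lower number here means a stronger inhibitor of growth, a higher number a weaker inhibitor of growth), compound 1 gives 42500 nM. For compound 2 this assay reports only a limit, > 100000 nM. Compound 3 gives 16500 nM in this assay, the lowest of the two numbers; its nearest neighbour is compound 1, and the step of a 2.6-fold lower number from compound 1 to compound 3 (0.41 log units; beyond the scatter) carries the whole difference between them.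

Compound 4 `O[C@H](COCCOC[C@@H](O)Cc1cn(-c2cncc3ccccc23)nn1)Cc1ccc(-c2ccccc2)cc1` differs from compound 3 in one place: isoquinolin-4-yl in place of 2,3-dihydro-1,4-benzodioxin-6-yl on an aromatic nitrogen. Within the data shown here, two measured steps bear on this position. The step of an at least 6.0-fold lower number from compound 2 to compound 3 (0.78 log units; beyond the scatter) shows that an aromatic group on this nitrogen in place of hydrogen lowers the number, while the step of a 2.6-fold lower number from compound 1 to compound 3 (0.41 log units; beyond the scatter) shows that exchanging one bicyclic aromatic group for another moves the number only modestly. Compound 4 keeps an aromatic bicycle at this nitrogen, so a change no larger than that modest swap is expected, with the direction open. Compound 4 is therefore estimated at 22000 nM, within a range from 8000 nM to 60000 nM, which would mean an expected step of a 1.3-fold higher number from compound 3 to compound 4 (0.12 log units; within the scatter).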

Compound 4, concentration for 50% growth inhibition: 17800 nM
Compound 4: the middle estimate sits 1.2-fold (0.09 log units) above what was measured; the range from low to high includes it.
By their numbers in this assay, from the lowest: compounds 3 and 4 (each within the scatter of the next); then compound 1. At a limit, above all of these: compound 2.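

The result in this assay is a 1.1-fold higher number from compound 3 to compound 4 (0.03 log units; within the scatter) and shows that on this aromatic nitrogen isoquinolin-4-yl and 2,3-dihydro-1,4-benzodioxin-6-yl cannot be told apart, although one group has a second aromatic ring with a ring nitrogen and the other a non-aromatic ring with two oxygens. The other new steps are a 2.4-fold lower number from compound 1 to compound 4 (0.38 log units; beyond the scatter) and an at least 5.6-fold lower number from compound 2 to compound 4 (0.74 log units; beyond the scatter) so a second group on this nitrogen repeats what compound 3 showed against both compounds. The second of these steps rests on a limit of the assay and not on a number: the limit of > 100000 nM in this assay, at which 1 of the 4 values shown sits.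

The compounds shown leave open whether a single ring such as phenyl, or a small group such as methyl, would serve on this nitrogen as the two bicyclic groups do. They also leave open whether an amine or a carboxylic acid on the aromatic ring attached here would change the number.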